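Moving the fluorine on the ring nitrogen's aryl group

A few compounds are considered here, and "the series" means these few. Any claim that something is new, unique, unknown or untested is made for them only; others in the source may bear on it.

Of the compounds shown here, two with a shared core have been tested so far. Compound 1 `COc1ccc(C)cc1N1C(=O)CSC1c1cccc(C(=O)NCCCCc2ccccc2)c1` gives 42% in a functional assay on HOS cells (Homo sapiens) for inhibition, read by CCK-8 assay, with a stated time of 72 h, tested at 1 uM; on this read-out higher numbers stand for more inhibition at the one concentration tested (going by the name of the read-out) and lower numbers for less inhibition. Compound 2 `O=C(NCCCCc1ccccc1)c1cccc(C2SCC(=O)N2c2cccc(F)c2)c1` gives 84% in this assay, the higher of the two numbers, with the step of a number 42 percentage points higher from compound 1 to compound 2 (beyond the scatter) lying beyond the scatter. Compound 3 `O=C(NCCCCc1ccccc1)c1cccc(C2SCC(=O)N2c2ccccc2F)c1` is not yet measured. It differs from compound 2 as follows: 2-fluorophenyl in place of 3-fluorophenyl on an amide-type nitrogen in a ring. Among the measured compounds shown here, the only measured step, from compound 1 to compound 2, changed the same aryl group on the ring nitrogen and was large, which shows that this group strongly affects the read-out. For the measured compounds named here, no measured step compares two fluorophenyl groups, so the size of the change is uncertain. A modest drop in this assay is expected for compound 3, with the step of a number 19 percentage points lower from compound 2 to compound 3 (beyond the scatter). The estimate for compound 3 is 65%, ranging from 35% to 90%.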

Compound 3, a percentage reported as inhibition, at one concentration (the size of the read-out at that concentration, not a potency): 83%
Compound 3: middle estimate off by 18 percentage points, on the low side, and the stated range covers the measured number.
By their numbers in this assay, from the lowest: compound 1; then compounds 3 and 2 (each within the scatter of the next).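

In this assay, 2-fluorophenyl in place of 3-fluorophenyl on the amide-type nitrogen in the ring gives a number 1 percentage points lower from compound 2 to compound 3 (within the scatter) and so does not separate these two fluorophenyl groups at this position. The large step seen earlier appears again with the other fluorophenyl group, as a number 41 percentage points higher from compound 1 to compound 3 (beyond the scatter) shows, and since 2-methoxy-5-methylphenyl and 2-fluorophenyl both carry a group numbered 2, a group there does not by itself go with the lower number. No measurement at hand explains these results.

As far as these compounds go, whether the methoxy or the methyl group of compound 1 goes with its lower number stays open, as does how 4-fluorophenyl, plain phenyl or 2-chlorophenyl would read here. Numbers from a single concentration also say little about how compound 2 and compound 3 would compare at lower concentrations.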